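Swapping Methyl for Pyridin-4-yl on a Ring Nitrogen

This account rests on a few compounds, and the source may have more. Where it says the series, first, only, none or still open, it means among the compounds named here.

Measured compounds:
compound 1, `Nc1ccccc1NC(=O)c1ccc(CSC(=S)N2CCN(c3cccnc3)CC2)cc1`, gives 27.6%
compound 2, `CN1CCN(C(=S)SCc2ccc(C(=O)Nc3ccccc3N)cc2)CC1`, gives 29.6%

Of the compounds shown here, two have been measured in a functional assay on MGC-803 cells (Homo sapiens) for antiproliferative activity, read by CCK-8 assay, with a stated time of 72 h, tested at 2 uM; on this read-out lower numbers stand for a weaker effect and higher numbers for a stronger effect at the one concentration tested. Compound 1 gives 27.6%, and compound 2 gives 29.6%. They differ at one place only: the step is a number 2 percentage points higher from compound 1 to compound 2 (within the scatter). On the two numbers available compound 2 carries the larger figure, but its nearest neighbour, compound 1, sits within the scatter of it, so no order between the two can be claimed.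

Compound 3, `Nc1ccccc1NC(=O)c1ccc(CSC(=S)N2CCN(c3ccncc3)CC2)cc1`, has not yet been measured. It is derived from compound 2 by the following change: pyridin-4-yl in place of methyl on an amine nitrogen in a ring. Among the measured compounds shown here, the only measured step that bears on this is the one from compound 1 to compound 2, where a pyridinyl group gave way to methyl at the same ring nitrogen with a difference within the scatter. The reverse type of change, methyl to a pyridinyl, is therefore expected to move this assay by no more than the scatter, in no particular direction.

Compound 3 is thus estimated at 28%, within a range of 15% to 42%. The expected step is a number 1.6 percentage points lower from compound 2 to compound 3 (within the scatter).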

Compound 3, a percentage reported as inhibition, at one concentration (the size of the read-out at that concentration, not a potency): 64.8%
The estimate for compound 3 lay 36.8 percentage points below the measured number, outside the stated range (above it).
By their numbers in this assay, from the lowest: compounds 1 and 2 (each within the scatter of the next); then compound 3.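

In this assay, the amine nitrogen in the ring proves sensitive to what it carries: pyridin-4-yl in place of methyl gives a number 35.2 percentage points higher from compound 2 to compound 3 (beyond the scatter) and thereby separates a position that had seemed indifferent to the change. The aromatic ring alone does not account for the rise, since pyridin-4-yl in place of pyridin-3-yl gives a number 37.2 percentage points higher from compound 1 to compound 3 (beyond the scatter) even though both groups are pyridinyl rings and the earlier exchange of pyridin-3-yl for methyl gave only a number 2 percentage points higher from compound 1 to compound 2 (within the scatter); what matters here is which pyridinyl isomer sits on the nitrogen, not simply the presence of such a ring. No measurement shown explains why these two isomers differ so widely in this assay.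

Among the compounds shown here, whether phenyl, which has no ring nitrogen, or pyridin-2-yl would stand with compound 3 or with the two lower compounds remains open, so the shape of this preference is known from only three groups. Each figure also comes from a single concentration, which leaves the potency of the three compounds undetermined.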